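The source may report more compounds than this note shows. Statements on the series, on what has been measured and on what is new or still open speak of the compounds shown alone.

Measured compounds in a functional assay on HL-60 cells (Homo sapiens) for cytotoxicity, read by luminescence and CellTiter-Glo, with a stated time of 3 days; on this read-out lower numbers stand for stronger inhibition and higher numbers for weaker inhibition:

- compound 1, `O=C(Nc1cc(C(F)(F)F)cc(C(F)(F)F)c1)c1cc(Cl)c(F)cc1O`: 430 nM
- compound 2, `O=C(Nc1cc(C(F)(F)F)cc(C(F)(F)F)c1)c1cc(Br)c(F)cc1O`: 250 nM
- compound 3, `O=C(Nc1ccc(Cl)c(Cl)c1)c1cc(F)ccc1O`: 660 nM

Compound 1 and compound 2 share one core; compound 3 carries another, and the difference between the two cores is not broken down here. Within the first core the single change is bromo in place of chloro on an aromatic carbon, and in this assay it gave a 1.7-fold lower number from compound 1 to compound 2 (0.24 log units; within the scatter).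

Compound 4, `O=C(Nc1ccc(Br)c(Cl)c1)c1cc(F)ccc1O`, is not yet measured. It stands to compound 3 as compound 2 stands to compound 1: the change is bromo in place of chloro on an aromatic carbon. This is the same kind of change, not the same one. In compound 2 the entering bromo sits ortho to a fluoro group, meta to a large group and para to a hydroxy group; in compound 4 it sits ortho to a chloro group and para to a large group.

Going by the values given here, with only one earlier instance, and that one within the scatter, the expectation for compound 4 is a small step, a 1.5-fold lower number from compound 3 to compound 4 (0.17 log units; within the scatter), resting on the size of the step from compound 1 to compound 2. The estimate for compound 4 in this assay is 450 nM, between 230 nM and 900 nM.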

Compound 4, half-maximal inhibitory concentration: 600 nM
Compound 4: middle estimate off by 1.3-fold (0.12 log units), on the low side; measured number inside the range.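

Bromo in place of chloro on an aromatic carbon now stands on two cores in this assay, and the new step is a 1.1-fold lower number from compound 3 to compound 4 (0.04 log units; within the scatter). Set beside the earlier step, the two do not separate: the same change on two cores in this assay, a 1.7-fold lower number (0.24 log units; within the scatter) from compound 1 to compound 2 and a 1.1-fold lower number (0.04 log units; within the scatter) from compound 3 to compound 4, 1.6-fold (0.19 log units) apart, within the scatter of two such steps. This shows that the change carries to the core of compound 3 with no step beyond the scatter, but it does not show a real gain from bromo on either core, and it cannot separate the effect of the core from that of the place, since the bromo in compound 4 sits ortho to a chloro group and para to a large group.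

The compounds shown leave open how this place responds to a group other than a halogen, such as a nitrile, a methoxy group or an amine. Also open, on these data alone, is what happens on either core when the hydroxy group gives way to a methoxy group or the amide gives way to a different link.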